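The source may hold more compounds than are shown below. What is called first, only, known or untested is meant among the compounds shown, and "the series" means these compounds.

Measured so far:
compound 1 `c1cncc(-c2ccccc2OCC2=NCCN2)c1` — 2 nM
compound 2 `c1cnc(-c2ccccc2OCC2=NCCN2)nc1` — 1260 nM
compound 3 `c1ccc(-c2ccoc2)c(OCC2=NCCN2)c1` — 0.501 nM

In a functional assay for activation of Alpha-1A adrenergic receptor (Homo sapiens), read by calcium flux (a higher number here means that more compound is needed for the effect, a lower number that less compound is needed), compound 1 stands second highest of the three numbers: compound 3 gives a lower number, compound 2 a far higher one. Compound 4 `c1ccc(-c2cc[nH]n2)c(OCC2=NCCN2)c1` has not been measured. The change from compound 1 is 1H-pyrazol-3-yl in place of pyridin-3-yl on an aromatic carbon. Within the data shown here, two measured steps bear on it. a 4.0-fold lower number from compound 1 to compound 3 (0.60 log units; beyond the scatter), where a five-membered aromatic ring also replaced pyridin-3-yl, points toward a lower number. a 630-fold higher number from compound 1 to compound 2 (2.80 log units; beyond the scatter), where an aromatic ring with 2 hetero atoms entered, points toward a much higher number. The new group shares features of both, so the direction is uncertain; a modest rise is expected, a 3.0-fold higher number from compound 1 to compound 4 (0.48 log units; beyond the scatter). Compound 4 is therefore estimated at 6 nM, within 0.8 nM to 80 nM.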

Compound 4, half-maximal effective concentration: 5.01 nM
Beside the measured number, compound 4's estimate is 1.2-fold (0.08 log units) above it; measured number inside the range.
By their numbers in this assay, from the lowest: compound 3; then compound 1; then compound 4; then compound 2.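

In this assay, an aromatic ring with 2 hetero atoms need not cost much at this position: a 250-fold lower number from compound 2 to compound 4 (2.40 log units; beyond the scatter), so 1H-pyrazol-3-yl lies far closer to the other groups than pyrimidin-2-yl does. A five-membered ring alone does not ensure a lower number either: a 10-fold higher number from compound 3 to compound 4 (1.00 log units; beyond the scatter), and a 2.5-fold higher number from compound 1 to compound 4 (0.40 log units; beyond the scatter). No measurement here accounts for these differences.

Still open, going by these compounds, is how a plain phenyl or a thiophene would behave on this carbon. A methyl group on the pyrazole nitrogen would test whether that ring's hydrogen matters.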